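The source may hold more compounds than are shown below. What is called first, only, known or untested is meant among the compounds shown, and "the series" means these compounds.

Of the compounds shown here, three sharing one core have been tested in a functional assay on KYSE-450 cells (Homo sapiens) for inhibition, read by CCK-8 assay, with a stated time of 48 h; on this read-out lower numbers stand for stronger inhibition and higher numbers for weaker inhibition. Compound 1 `COc1ccc(CN(C(=O)CSC(=S)N2CCOCC2)c2cc(OC)c(OC)c(OC)c2)cc1` gives 7220 nM, and compound 3 `COc1ccc(CN(C(=O)CSC(=S)N2CCc3cc(OC)ccc32)c2cc(OC)c(OC)c(OC)c2)cc1` gives 10200 nM, so these two sit within the scatter of each other. Compound 2 `COc1ccc(CN(C(=O)CSC(=S)N2CCc3cc(Br)ccc32)c2cc(OC)c(OC)c(OC)c2)cc1` is reported only as a limit, > 20000 nM.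

The next candidate is compound 4 `COc1ccc(CN(C(=O)CSC(=S)N2CCc3ccccc3C2)c2cc(OC)c(OC)c(OC)c2)cc1`, which differs from compound 3 on a thiocarbonyl carbon: 1,2,3,4-tetrahydroisoquinolin-2-yl in place of 5-methoxy-2,3-dihydro-1H-indol-1-yl on a thiocarbonyl carbon. For the measured compounds named here, no tested compound carries the 1,2,3,4-tetrahydroisoquinolin-2-yl group, so the evidence is indirect. Exchanging morpholin-4-yl for 5-methoxy-2,3-dihydro-1H-indol-1-yl gave a 1.4-fold higher number from compound 1 to compound 3 (0.15 log units; within the scatter). The 5-bromo-2,3-dihydro-1H-indol-1-yl group gave an at least 2.7-fold higher number from compound 1 to compound 2 (0.44 log units; beyond the scatter), and methoxy in place of bromo gave an at least 1.9-fold lower number from compound 2 to compound 3 (0.29 log units; that floor lies within the scatter). Only the bromo group moved the number beyond the scatter, and compound 4 carries neither bromo nor methoxy. With a 1.4-fold higher number from compound 1 to compound 3 (0.15 log units; within the scatter) as the closest guide, no step beyond the scatter is expected in this assay. The estimated change is a 1.3-fold lower number from compound 3 to compound 4 (0.11 log units; within the scatter). For compound 4 the expected value is 8000 nM, with an estimated range from 2500 nM to 20000 nM.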

Compound 4, half-maximal inhibitory concentration: > 20000 nM
Compound 4: no number, only a limit; the forecaster's own chance of this, stated with the estimate: 20%; at least 2.5-fold (0.39 log units) between middle value and limit.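

The result shows that a bromo group is not required for a step beyond the scatter at this position: on the thiocarbonyl carbon, 1,2,3,4-tetrahydroisoquinolin-2-yl in place of morpholin-4-yl gives an at least 2.7-fold higher number from compound 1 to compound 4 (0.44 log units; beyond the scatter). The exchange of 5-methoxy-2,3-dihydro-1H-indol-1-yl for the same group gives an at least 1.9-fold higher number from compound 3 to compound 4 (0.29 log units; that floor lies within the scatter), so this comparison alone does not establish a change beyond the scatter. The step between compound 2 and compound 4 cannot be read, as both values are limits: the limit of > 20000 nM in this assay, at which 2 of the 4 values shown sit.

As far as these compounds go, how far compound 2 and compound 4 lie past that limit remains open, and so does any order between them. Also open, from the compounds shown here alone, is whether piperidin-1-yl or a dimethylamino group on the thiocarbonyl carbon would give a number near that of compound 1 or would reach the limit.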